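A few compounds are considered here, and "the series" means these few. Any claim that something is new, unique, unknown or untested is made for them only; others in the source may bear on it.

Measured so far in a functional assay on HCT-116 cells (Homo sapiens) for inhibition, read by MTT assay, with a stated time of 48 h; a lower number here means a stronger inhibitor, a higher number a weaker inhibitor:
compound 1 `O=C(CSc1nnc(-c2ccncc2)n1-c1ccccc1)N/N=C/c1ccccc1F` — 18000 nM
compound 2 `O=C(CSc1nnc(-c2ccncc2)n1-c1ccccc1)N/N=C/c1ccc(O)c(O)c1` — 14700 nM

Compound 2 stands with the lower of the two numbers, but the step of a 1.2-fold lower number from compound 1 to compound 2 (0.09 log units; within the scatter) lies within the scatter, so the two compounds are not separated. Compound 3 `O=C(CSc1nnc(-c2ccncc2)n1-c1ccccc1)N/N=C/C=C/c1ccccc1` differs from compound 2 by 2-phenylethenyl in place of 3,4-dihydroxyphenyl on a carbon with a double bond to nitrogen. Within the data shown here, the only measured step at this carbon, a 1.2-fold lower number from compound 1 to compound 2 (0.09 log units; within the scatter), was within the scatter, and no step bears on a phenylethenyl group, so no change beyond the scatter is expected in this assay. Compound 3 is estimated at 16000 nM, range 6000 nM to 45000 nM, a step of a 1.1-fold higher number from compound 2 to compound 3 (0.04 log units; within the scatter).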

Compound 3, half-maximal inhibitory concentration: 6150 nM
Beside the measured number, compound 3's estimate is 2.6-fold (0.42 log units) above it; the measured number falls inside the stated range.
By their numbers in this assay, from the lowest: compound 3; then compounds 2 and 1 (each within the scatter of the next).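

At the carbon with a double bond to nitrogen, this assay now separates the groups: 2-phenylethenyl gives a lower number than 3,4-dihydroxyphenyl (a 2.4-fold lower number from compound 2 to compound 3 (0.38 log units; beyond the scatter)) and than 2-fluorophenyl (a 2.9-fold lower number from compound 1 to compound 3 (0.47 log units; beyond the scatter)), both modest steps. Among these compounds, these are the first steps at this position beyond the scatter, and 2-phenylethenyl is the only group here with a double bond outside aromatic rings. No evidence on the origin of these steps is at hand.

As far as these compounds go, whether that double bond is required remains open. A saturated 2-phenylethyl group, or an amine on the ring of 2-phenylethenyl, would extend the comparison.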